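A few compounds are considered here, and "the series" means these few. Any claim that something is new, unique, unknown or untested is made for them only; others in the source may bear on it.

Notes on the series. In a physicochemical assay for lipophilicity, measured as octanol-water partition, at pH 7.4 (on this read-out higher numbers stand for higher lipophilicity and lower numbers for lower lipophilicity), compound 1 (`Cc1ccc2[nH]c(C(=O)N[C@H]3CN(S(=O)(=O)c4ccccc4)C[C@@H]3C(=O)NCCN(C)C)cc2c1`) gives 2.1 and compound 2 (`Cc1ccc2[nH]c(C(=O)N[C@H]3CN(S(=O)(=O)c4cnccn4)C[C@@H]3C(=O)NCCN(C)C)cc2c1`) gives 1. Compound 3 (`Cc1ccc2[nH]c(C(=O)N[C@H]3CCN(S(=O)(=O)c4ccccc4)C[C@@H]3C(=O)NCCN(C)C)cc2c1`) gives 2.2, which is within the scatter of the number for compound 1 and beyond the scatter from the number for compound 2. Compound 3 and compound 1 therefore share the upper end of the three measured numbers.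

The next compound is compound 4 (`Cc1ccc2[nH]c(C(=O)N[C@H]3CCN(S(=O)(=O)C4CC4)C[C@@H]3C(=O)NCCN(C)C)cc2c1`). The change from compound 3 is cyclopropyl in place of phenyl on a sulfonyl sulfur whose other neighbours are a sulfonamide nitrogen in a ring.

For the measured compounds named here, only one measured step bears on this change: a number 1.10 log units lower from compound 1 to compound 2 (beyond the scatter), a large step beyond the scatter, with pyrazin-2-yl in place of phenyl on a sulfonyl sulfur. It also removes the phenyl, but it brings in a different group on a different core, so it is only a loose guide. Going by the values given here, no measured step brings in cyclopropyl. A fall in this assay is expected, smaller than that step but still likely beyond the scatter. The expected step is a number 0.60 log units lower from compound 3 to compound 4 (beyond the scatter). For compound 4 the estimated value is 1.6, with an expected range from 1.2 to 2.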

Compound 4, distribution coefficient: 1
For compound 4 the middle estimate is 0.60 log units above the measured one, and the stated range ends above it.
By their numbers in this assay, from the lowest: compounds 2 and 4 (each within the scatter of the next); then compounds 1 and 3 (each within the scatter of the next).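

Cyclopropyl in place of phenyl on a sulfonyl sulfur gives a number 1.20 log units lower from compound 3 to compound 4 (beyond the scatter) in this assay, so this position also carries a large change on the core of compound 3, where the sulfonamide nitrogen is in a ring. For the compounds shown here, the entering group here is a three-membered non-aromatic ring of carbon only, with no hydrogen-bond donors or acceptors, so a large fall on leaving phenyl does not require ring nitrogen in the new group, as pyrazin-2-yl on the other core might have suggested with a number 1.10 log units lower from compound 1 to compound 2 (beyond the scatter) as the only earlier step at this position. Both replacements of phenyl shown so far lie beyond the scatter, and no compound here goes against that, though the data offer no measured explanation for the size of the new step.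

Still open, as far as these compounds go, is whether the fall follows the loss of the aromatic ring or the drop in heavy atoms, a question that a cyclohexyl or a tert-butyl group on the same sulfonyl sulfur would address. Also open, from the compounds shown here alone, is whether pyrazin-2-yl on the core of compound 3 would behave as it does on the core of compound 1, and whether a simple methyl group would extend the trend.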